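Trading an Amine Chain for an Oxanyl Ether

This account rests on a few compounds, and the source may have more. Where it says the series, first, only, none or still open, it means among the compounds named here.

In a functional assay on RS4-11 cells (Homo sapiens) for inhibition, read by CCK-8 assay, with a stated time of 72 h (a higher number here means a weaker inhibitor, a lower number a stronger inhibitor), compound 1 (`CC1(C)CCC(CN2CCN(c3ccc(C(=O)NS(=O)(=O)c4ccc(NCC5CCOCC5)c([N+](=O)[O-])c4)c(Oc4cnc5[nH]ccc5c4)c3)CC2)=C(c2ccc(C(F)(F)F)c(Cl)c2)C1`) gives 81 nM and compound 2 (`CCN(CC)CCCNc1ccc(S(=O)(=O)NC(=O)c2ccc(N3CCN(CC4=C(c5ccc(C(F)(F)F)cc5)CC(C)(C)CC4)CC3)cc2Oc2cnc3[nH]ccc3c2)cc1[N+](=O)[O-]`) gives 3 nM as the lower of the two numbers, with a gap between them that lies beyond the usual scatter. These two compounds differ in more than one place, so the gap cannot be tied to any single change.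

Compound 3 (`CC1(C)CCC(CN2CCN(c3ccc(C(=O)NS(=O)(=O)c4ccc(OC5CCOCC5)c([N+](=O)[O-])c4)c(Oc4cnc5[nH]ccc5c4)c3)CC2)=C(c2ccc(C(F)(F)F)cc2)C1`) departs from compound 2 in one place only, where (oxan-4-yl)oxy stands in place of (3-(diethylamino)propyl)amino ((oxan-4-yl)oxy in place of (3-(diethylamino)propyl)amino on an aromatic carbon) on an aromatic carbon, ortho to a nitro group and para to a large group. Within the data shown here, no measured pair isolates this swap, so the forecast rests on thin evidence. Compound 1 also lacks the (3-(diethylamino)propyl)amino group and reads 81 nM in this comparison, which points to a higher number rather than a lower one. The expected change is a step of a 13-fold higher number from compound 2 to compound 3 (1.12 log units; beyond the scatter) toward weaker inhibition in this assay and beyond the scatter. For compound 3 the estimate is 40 nM with an expected range from 10 nM to 200 nM in this read-out.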

Compound 3, half-maximal inhibitory concentration: 375 nM
Compound 3: the middle estimate sits 9.4-fold (0.97 log units) below what was measured; the whole stated range lies below it.
By their numbers in this assay, from the lowest: compound 2; then compound 1; then compound 3.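

In this assay, replacing (3-(diethylamino)propyl)amino with (oxan-4-yl)oxy on this aromatic carbon, ortho to a nitro group and para to a large group, gives a 130-fold higher number from compound 2 to compound 3 (2.10 log units; beyond the scatter), a large step toward weaker inhibition. This is the first pair shown that differs in one place only, so a gap of this size can now be tied to a single position, and that position proves far from indifferent to the group it carries. No measurement of any property of the two groups accompanies the result, and the step therefore stands without an explanation.

The swap alters several features at once: the atom joining the group to the aromatic carbon, the open chain against the six-membered ring, and the diethylamino end, so the compounds shown cannot divide the step among them. An (oxan-4-yl)amino group at this position would separate the joining atom from the ring, while a 3-(dimethylamino)propoxy chain would test whether the amine end keeps its value with an oxygen as the joining atom.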